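From 3,4-Dimethoxyphenyl to 4-Chlorophenyl on the Shared Core

The source may hold more compounds than are shown below. What is called first, only, known or untested is meant among the compounds shown, and "the series" means these compounds.

Of the compounds shown here, two sharing one core have so far been measured in a functional assay on U-87MG ATCC cells for antiproliferative activity against U-87 MG (Homo sapiens), read by MTT assay, with a stated time of 48 h, tested at 100 uM; on this read-out lower numbers stand for a stronger effect and higher numbers for a weaker effect at the one concentration tested. Compound 1 `COc1ccc(-c2nc(SCC(=O)c3sc(-c4ccccc4)nc3C)[nH]c(=O)c2C#N)cc1OC` gives 6.48%, the lower of the two numbers and therefore the stronger effect seen. Compound 2 `COc1ccc(-c2nc(SCC(=O)c3sc(-c4ccc(Cl)cc4)nc3C)[nH]c(=O)c2C#N)cc1OC` gives 18.7%. For the measured compounds named here, the one measured step, a number 12.2 percentage points higher from compound 1 to compound 2 (beyond the scatter), comes from a chloro in place of hydrogen on an aromatic carbon and points toward a weaker effect.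

Compound 3 `Cc1nc(-c2ccccc2)sc1C(=O)CSc1nc(-c2ccc(Cl)cc2)c(C#N)c(=O)[nH]1` differs from compound 1 in a different place: 4-chlorophenyl in place of 3,4-dimethoxyphenyl on an aromatic carbon. Going by the values given here, no measured step touches this part of the molecule, so the step from compound 1 to compound 2 bears on it only loosely, as the only hint available, and it shows that bringing a chlorine onto an aromatic ring was followed by a modest rise. On that thin basis compound 3 is expected to sit somewhat higher than compound 1, a number 9.5 percentage points higher from compound 1 to compound 3 (within the scatter), toward a weaker effect, although a step within the scatter remains possible. The estimate for compound 3 is 16%, expected to fall between 3% and 40%.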

Compound 3, a percentage reported as activity, at one concentration (the size of the read-out at that concentration, not a potency): 22.5%
The estimate for compound 3 lay 6.5 percentage points below the measured number; low and high end bracket the measured number.
By their numbers in this assay, from the lowest: compound 1; then compounds 2 and 3 (each within the scatter of the next).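

For the compounds shown here, this is the first measured change at this position, on the aromatic carbon ortho to a cyano group: in this assay, 4-chlorophenyl in place of 3,4-dimethoxyphenyl gives a number 16 percentage points higher from compound 1 to compound 3 (beyond the scatter), so the group held here does affect the read-out, and the 3,4-dimethoxyphenyl of compound 1 goes with the stronger effect of this pair. The swap alters several things at once. The leaving group has 10 heavy atoms and 2 hydrogen-bond acceptors while the entering group has 7 heavy atoms and 0 hydrogen-bond acceptors, and it also brings in a chlorine, so this one step cannot show which of these differences matters. No measurement available here explains the higher number.

The compounds shown leave open how a plain phenyl, a phenyl with a single methoxy group or a phenyl carrying an amine would read at this position, any of which would help separate losing the methoxy groups from gaining the chlorine. They also leave open whether this swap would give a similar step on a compound that keeps the chloro of compound 2 elsewhere in the molecule.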